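Morpholine Dithiocarbamate Side Chain in Place of Benzyl

A few compounds are considered here, and "the series" means these few. Any claim that something is new, unique, unknown or untested is made for them only; others in the source may bear on it.

For the measured compounds named here, in a functional assay on SW-620 cells (Homo sapiens) for inhibition, read by MTT assay, with a stated time of 72 h (on this read-out lower numbers stand for stronger inhibition and higher numbers for weaker inhibition), compound 3 `O=c1cc(Cn2cc(CCc3ccccc3)nn2)c2ccc(O)cc2o1` gives 84400 nM, and this is the only true number among the three values shown. Compound 1 `O=c1cc(Cn2cc(CCCO)nn2)c2ccc(O)cc2o1` reaches only the limit of the assay, > 100000 nM. Compound 2 `O=c1cc(Cn2cc(CCCCO)nn2)c2ccc(O)cc2o1` likewise reaches only that limit, > 100000 nM. Those two limits are the limit of > 100000 nM in this assay, at which 2 of the 3 values shown sit. Between those two the step cannot be read: a step that the two limits leave unreadable from compound 1 to compound 2. Going by the values given here, the steps to the one real number are floors only: an at least 1.1-fold lower number from compound 1 to compound 3 (0.07 log units; that floor lies within the scatter) and an at least 1.1-fold lower number from compound 2 to compound 3 (0.07 log units; that floor lies within the scatter).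

Compound 4 `O=c1cc(Cn2cc(CSC(=S)N3CCOCC3)nn2)c2ccc(O)cc2o1` carries a group of 9 heavy atoms (5 carbon, 1 nitrogen, 1 oxygen, 2 sulfur; one six-membered non-aromatic ring with 2 hetero atoms) in place of a group of 7 heavy atoms (7 carbon; one six-membered aromatic ring of carbon only), on a saturated chain carbon bound to an aromatic carbon. Among the compounds with values here, none of the measured steps exchanges the benzyl for anything resembling this group; the two readable floors show only that compound 3 sits somewhat under the limit, by amounts within the scatter. Within the data shown here, no measured step therefore sets a direction for this change in this assay, and the expectation is a number close to that of compound 3, with a wide range to cover the lack of guidance. For compound 4 the estimate is 70000 nM, between 15000 nM and 300000 nM. This estimate means an expected step of a 1.2-fold lower number from compound 3 to compound 4 (0.08 log units; within the scatter), within the scatter.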

Compound 4, half-maximal inhibitory concentration: >= 100000 nM
Compound 4 ended at the assay's limit (the forecaster's own chance of this, stated with the estimate: 40%); at least 1.4-fold (0.15 log units) between middle value and limit.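

The new point is that a side chain holding sulfur and a non-aromatic ring, on a saturated chain carbon bound to an aromatic carbon, leaves this assay with no true number for compound 4, only a limit: the limit of >= 100000 nM in this assay, at which 1 of the 4 values shown sits. Against benzyl the result gives only a floor, an at least 1.1-fold higher number from compound 3 to compound 4 (0.07 log units; that floor lies within the scatter), so it cannot say whether this exchange costs anything real, or how much. The steps to compound 4 from compound 1 and from compound 2 join two limits and cannot be read, so the morpholine dithiocarbamate side chain cannot be ranked against the hydroxy-ending chains.

For the compounds shown here, compound 3 therefore remains the only compound here with a true number, and it is still open whether any group at this place can bring the value far under the limit. A longer chain ending in phenyl, a phenyl ring carrying a chlorine atom, or a plain morpholine without the sulfur-containing link would each test a different part of this exchange, as would an amine or a carboxylic acid.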